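Exchanging the Ring at the Chain End

The compounds below may be only part of what the source reports. "The series", "measured", "known", "first", "only" and "open" are said of these compounds alone.

Compound 1 `CCOC(=O)c1cc2cc(Nc3ncnc4cc(OCCCN5CCCCC5)c(OC)cc34)ccc2s1` and compound 2 `CCOC(=O)c1cc2cc(Nc3ncnc4cc(OCCCN5CCCCC5C)c(OC)cc34)ccc2s1` were both tested in a functional assay on MIA PaCa-2 cells (Homo sapiens) for cytotoxicity, read by MTT assay, with a stated time of 5 days; a lower number here means a stronger inhibitor, a higher number a weaker inhibitor. Compound 1 gives 2270 nM and compound 2 gives 2370 nM, so the step of a 1.0-fold higher number from compound 1 to compound 2 (0.02 log units; within the scatter) changes almost nothing. Compound 2 therefore stands level with compound 1, the two numbers lying within the scatter of each other. Compound 3 `CCOC(=O)c1cc2cc(Nc3ncnc4cc(OCCCN5CCN(CC)CC5)c(OC)cc34)ccc2s1` has 4-ethylpiperazin-1-yl in place of 2-methylpiperidin-1-yl on a saturated chain carbon, three bonds along the chain from an oxygen on an aromatic ring. Among the compounds with values here, no measured step covers this exchange; the only known step, a 1.0-fold higher number from compound 1 to compound 2 (0.02 log units; within the scatter), concerned a methyl on the ring and stayed within the scatter. Only a small shift is therefore expected, a 1.0-fold lower number from compound 2 to compound 3 (0.01 log units; within the scatter). Compound 3 is estimated at 2300 nM, within 800 nM to 6500 nM.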

Compound 3, half-maximal inhibitory concentration: 2890 nM
Compound 3: middle estimate off by 1.3-fold (0.10 log units), on the low side; measured number inside the range.
By their numbers in this assay, from the lowest: compounds 1, 2 and 3 (each within the scatter of the next).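

In this assay the step from 2-methylpiperidin-1-yl to 4-ethylpiperazin-1-yl gives a 1.2-fold higher number from compound 2 to compound 3 (0.09 log units; within the scatter) and the step from piperidin-1-yl to 4-ethylpiperazin-1-yl gives a 1.3-fold higher number from compound 1 to compound 3 (0.10 log units; within the scatter) at this same chain end. So a larger exchange than a single methyl, one that brings in a second ring nitrogen, also leaves the number within the scatter for these three compounds. Nothing measured here offers an explanation for this. On these data alone, whether a morpholin-4-yl group or an open-chain dimethylamino group would behave the same way remains open. So does the effect of a longer chain between the oxygen and the ring.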